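The source may hold more compounds than are shown below. What is called first, only, known or untested is meant among the compounds shown, and "the series" means these compounds.

In a functional assay on HeLa cells (Homo sapiens) for antiproliferative activity, read by MTT assay (a higher number here means a weaker inhibitor, a lower number a stronger inhibitor), compound 1 (`COc1ccc(-c2ccnc(Nc3ccc([N+](=O)[O-])cc3)n2)cc1`) gives 980 nM, the second highest of three numbers. Compound 2 (`COc1ccc(-c2ccnc(Nc3ccc(Cl)cc3)n2)cc1`) lies lower at 310 nM, and compound 3 (`COc1cccc(Nc2nccc(-c3ccc(Cl)cc3Cl)n2)c1`) lies higher at 76400 nM. Compound 4 (`O=[N+]([O-])c1ccc(Nc2nccc(-c3ccc(Cl)cc3Cl)n2)cc1`) keeps the nitro group of compound 1 and takes 2,4-dichlorophenyl in place of 4-methoxyphenyl (2,4-dichlorophenyl in place of 4-methoxyphenyl on an aromatic carbon). Among the compounds with values here, the only measured step (a 3.2-fold lower number from compound 1 to compound 2 (0.50 log units; beyond the scatter)) swaps chloro in place of nitro, so it gives no direct size for this change. Compound 3 (76400 nM) carries the same 2,4-dichlorophenyl but has no nitro group, so a clearly higher number is expected in this assay, with wide uncertainty. The expected step is large (a 15-fold higher number from compound 1 to compound 4 (1.18 log units; beyond the scatter)). The estimate for compound 4 is 15000 nM (expected range 2500 nM to 80000 nM).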

Compound 4, half-maximal inhibitory concentration: 168000 nM
The estimate for compound 4 lay 11-fold (1.05 log units) below the measured number; the measured number lies above the stated range.
By their numbers in this assay, from the lowest: compound 2; then compound 1; then compound 3; then compound 4.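

At this aromatic carbon next to the ring nitrogen, 2,4-dichlorophenyl in place of 4-methoxyphenyl gives a 170-fold higher number from compound 1 to compound 4 (2.23 log units; beyond the scatter) in this assay, a much larger step than a 3.2-fold lower number from compound 1 to compound 2 (0.50 log units; beyond the scatter) at the other end of the molecule. Compound 3, which also carries 2,4-dichlorophenyl, stands at 76400 nM, so both compounds with this group give high numbers. Nothing at hand explains the size of this step.

Still open, from the compounds shown here alone, is whether the rise follows the loss of the methoxy group or the arrival of either chlorine. A plain phenyl, a 4-chlorophenyl or a 4-aminophenyl at this carbon would separate these readings.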